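A Nitrile Swap at the Assay Limit

A few compounds are considered here, and "the series" means these few. Any claim that something is new, unique, unknown or untested is made for them only; others in the source may bear on it.

Measured in an ADME assay on Karpas-1106P cells (Homo sapiens) for cytotoxicity; a lower number here means that less compound is needed, a higher number that more compound is needed for the effect:
- compound 1 `Cc1ccc(S(=O)(=O)N[C@@H](CC(=O)NC(C)(C)C)C(=O)NCCNC(=O)c2cccc(C(C)C)c2)cc1`: > 11100 nM (a limit)
- compound 2 `Cc1ccc(S(=O)(=O)N[C@@H](CC(=O)NC(C)(C)C)C(=O)NCCNC(=O)c2ccccc2Cl)cc1`: > 11100 nM (a limit)
- compound 3 `Cc1ccc(S(=O)(=O)N[C@@H](CC(=O)NC(C)(C)C)C(=O)NCCNC(=O)c2ccc(F)cc2)cc1`: > 11100 nM (a limit)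

Compound 3 gives > 11100 nM, which is a limit and not a number. The whole measured set shows (the limit of > 11100 nM in this assay, at which 3 of the 3 values shown sit).

The next structure is compound 4 `Cc1ccc(S(=O)(=O)N[C@@H](CC(=O)NC(C)(C)C)C(=O)NCCNC(=O)c2cccc(C#N)c2)cc1`, which carries 3-cyanophenyl in place of 4-fluorophenyl on a carbonyl carbon.

Among the compounds with values here, two measured steps bear on this change, as both alter the group at the same place: a step that the two limits leave unreadable from compound 1 to compound 3 and a step that the two limits leave unreadable from compound 2 to compound 3. Neither has a readable size, so neither gives a measured size or direction to carry over. In this assay, the only expectation they support is that compound 4 stays with the other three, with no readable change.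

The expected change is a step that the limit leaves unreadable from compound 3 to compound 4. The estimate for compound 4 is 14000 nM, with an expected range of 7000 nM to 30000 nM, and a report as a limit is the likeliest outcome.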

Compound 4, half-maximal effective concentration: > 11100 nM
Compound 4 was reported as a limit; the forecaster's own chance of this, stated with the estimate: 85%; the middle value lies beyond the limit too.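

Compound 4 is also reported only as a limit, so its steps from compound 1, compound 2 and compound 3 cannot be read. All four compounds stand together: the limit of > 11100 nM in this assay, at which 4 of the 4 values shown sit.

The compounds shown leave open whether any group on this carbonyl carbon would give a readable value in this assay.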